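The compounds below may be only part of what the source reports. "The series", "measured", "known", "first", "only" and "open" are said of these compounds alone.

Measured compounds in a physicochemical assay for solubility, in phosphate buffer, with a stated time of 18 h; on this read-out higher numbers stand for higher solubility and lower numbers for lower solubility:
compound 1 `N#Cc1c(N)nc2nc(C3CC3)ncc2c1N` gives 23000 nM
compound 2 `N#Cc1c(N)nc2nc(C3CCCC3)ncc2c1N` gives 89000 nM
compound 3 `CC(C)(C)c1nc(CCCCCC#N)c2c(N)c(C#N)c(N)nc2n1` gives 6000 nM

Compound 3 stands lowest of the three numbers; compound 1 is nearest and compound 2 furthest, and both gaps lie beyond the scatter. Compound 4 `Cc1c[nH]c(-c2nc(C(C)(C)C)nc3nc(N)c(C#N)c(N)c23)n1` arises from compound 3 by a single change: 4-methyl-1H-imidazol-2-yl in place of 5-cyanopentyl on an aromatic carbon. Among the measured compounds shown here, the one measured step, a 3.9-fold higher number from compound 1 to compound 2 (0.59 log units; beyond the scatter), puts cyclopentyl in place of cyclopropyl on the shared core and does not match a trade of a chain for a five-membered aromatic ring with two hetero atoms. For the measured compounds named here, no matching step exists, so the expectation rests on compound 3 alone and carries a wide range. A modest step downward, a 2.0-fold lower number from compound 3 to compound 4 (0.30 log units; within the scatter), is expected. Compound 4 is estimated at 3000 nM in this assay, with a range from 600 nM to 15000 nM.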

Compound 4, solubility: 5000 nM
The estimate for compound 4 lay 1.7-fold (0.22 log units) below the measured number, and the stated range covers the measured number.
By their numbers in this assay, from the lowest: compounds 4 and 3 (each within the scatter of the next); then compound 1; then compound 2.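

At this aromatic carbon of the shared core, 4-methyl-1H-imidazol-2-yl in place of 5-cyanopentyl gives a 1.2-fold lower number from compound 3 to compound 4 (0.08 log units; within the scatter) in this assay. A chain with no ring and a five-membered aromatic ring with a hydrogen-bond donor thus read alike here, something the earlier step, made at a different place, could not show. Nothing measured explains this match.

Going by these compounds, whether an amine or a carboxylic acid at this carbon would also read alike stays open. So does whether the match holds with another group in place of tert-butyl.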